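The source may report more compounds than this note shows. Statements on the series, on what has been measured and on what is new or still open speak of the compounds shown alone.

Within the data shown here, in a functional assay on B16-F0 cells (Mus musculus) for inhibition, read by CCK-8 assay, with a stated time of 48 h (a lower number here means a stronger inhibitor, a higher number a weaker inhibitor), compound 1, `COc1cc(-c2ccnc3cc(-c4ccc(Cl)cc4)nn23)cc(OC)c1OC`, gives 4090 nM, the only outright number among the three compounds measured so far. Compound 2, `CCOC(=O)c1ccc(-c2cc3nccc(-c4cc(OC)c(OC)c(OC)c4)n3n2)cc1`, reaches only the limit of this assay, > 10000 nM. Compound 3, `COc1cc(-c2ccnc3cc(-c4cccc(C#N)c4)nn23)cc(OC)c1OC`, likewise stops at the limit, > 10000 nM. Compound 4, `COc1cc(-c2ccnc3cc(-c4ccc(C(F)(F)F)cc4)nn23)cc(OC)c1OC`, has not yet been measured; it differs from compound 1 by trifluoromethyl in place of chloro on an aromatic carbon. Two measured steps alter the same outer ring of the shared core. The first, an at least 2.4-fold higher number from compound 1 to compound 2 (0.38 log units; beyond the scatter), and the second, an at least 2.4-fold higher number from compound 1 to compound 3 (0.38 log units; beyond the scatter), both weakened inhibition, and their true size is known only as a lower bound because the limit of > 10000 nM in this assay, at which 2 of the 3 values shown sit, caps what could be read. Both replacements of the chloro group of compound 1 seen so far weakened the inhibitor, so a weaker number is expected for compound 4 as well, though not necessarily one that runs off the scale. The step is expected to be a 1.8-fold higher number from compound 1 to compound 4 (0.26 log units; within the scatter). Compound 4 is therefore estimated at 7500 nM, within 3000 nM to 20000 nM.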

Compound 4, half-maximal inhibitory concentration: 1770 nM
The estimate for compound 4 lay 4.2-fold (0.63 log units) above the measured number, outside the stated range (below it).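

Replacing chloro with trifluoromethyl at this place, para to a large group, gives a stronger inhibitor, with a 2.3-fold lower number from compound 1 to compound 4 (0.36 log units; beyond the scatter) in the read-out, so not every replacement of chloro here weakens inhibition. The trifluoromethyl compound also stands clear of the two weaker compounds, with an at least 5.6-fold lower number from compound 3 to compound 4 (0.75 log units; beyond the scatter) and with an at least 5.6-fold lower number from compound 2 to compound 4 (0.75 log units; beyond the scatter) in the read-out. Those two steps are only lower bounds, because the true sizes are capped: the limit of > 10000 nM in this assay, at which 2 of the 4 values shown sit.

On these data alone, it remains open whether the gain is special to trifluoromethyl or would also appear with a bromo, a methyl or an amine at the same place. The compounds shown also leave the rest of the shared core unchanged, so they do not tell how this gain would hold up alongside a change elsewhere.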